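Swapping the dimethoxyphenyl ring on the oxadiazoline core

A few compounds are considered here, and "the series" means these few. Any claim that something is new, unique, unknown or untested is made for them only; others in the source may bear on it.

Compounds measured so far:
compound 1, `COc1ccc(C2OC(c3cc(OC)c(OC)c(OC)c3)=NN2C(C)=O)c(OC)c1`, 6.3%;
compound 2, `COc1cc(C(=O)N/N=C/c2ccccc2F)cc(OC)c1OC`, 51.6%;
compound 3, `COc1cc(C2=NN(C(C)=O)C(c3cc(OC)c(OC)c(OC)c3)O2)cc(OC)c1OC`, -1.8%.

In a functional assay on BGC-823 cells (Homo sapiens) for antiproliferative activity, read by MTT assay, tested at 1 uM (on this read-out lower numbers stand for a weaker effect and higher numbers for a stronger effect at the one concentration tested), compound 1 gives 6.3%. Compound 3, which shares the same core with a trimethoxyphenyl group in place of the dimethoxyphenyl one, gives -1.8%; the two numbers lie within the usual scatter of each other, so nothing separates them. Compound 2, the open-chain hydrazone, gives 51.6%, a number that stands beyond the scatter above compound 1. Compound 1 therefore sits in the weak region of the three results, close to compound 3 and far from compound 2.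

Compound 4, `COc1cc(C2=NN(C(C)=O)C(c3ccc(Cl)c([N+](=O)[O-])c3)O2)cc(OC)c1OC`, is not yet measured. It differs from compound 1 in one place: 4-chloro-3-nitrophenyl in place of 2,4-dimethoxyphenyl on a saturated ring carbon. The acetylated five-membered ring and the trimethoxyphenyl group are unchanged. Going by the values given here, both ring-closed compounds measured so far, compound 1 and compound 3, gave weak numbers, and no pair of measured compounds shows how a change on this saturated ring carbon moves the result. The step from compound 1 to compound 4 is therefore expected to be small, a number 5.7 percentage points higher from compound 1 to compound 4 (within the scatter), and most likely within the scatter, with an upward direction if anything. Compound 4 is estimated to give 12%, in a range from -8% to 38%.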

Compound 4, a percentage reported as inhibition, at one concentration (the size of the read-out at that concentration, not a potency): -2.3%
Beside the measured number, compound 4's estimate is 14.3 percentage points above it, within the range that was stated.
By their numbers in this assay, from the lowest: compounds 4, 3 and 1 (each within the scatter of the next); then compound 2.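

In this assay, going by these compounds alone, the change gives a number 8.6 percentage points lower from compound 1 to compound 4 (within the scatter), and this is the first pair to isolate the group on the saturated ring carbon of the shared core. The 2,4-dimethoxyphenyl and 4-chloro-3-nitrophenyl groups differ in their substituents and atom make-up, yet at the one concentration tested this read-out does not separate them, so this single exchange at this position gives no measurable gain or loss of effect. No available measurement bears on why the two compounds cannot be told apart here.

The compounds shown leave open whether a different kind of group on this carbon, such as an aminophenyl ring, a phenyl ring carrying a carboxylic acid, or a longer alkyl chain, would move the number beyond the scatter. They also leave open whether a longer acyl chain, such as butanoyl, in place of the acetyl group on the ring nitrogen would change the result for compound 1 or compound 4.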